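Shortening one acyl chain on compound 3

A few compounds are considered here, and "the series" means these few. Any claim that something is new, unique, unknown or untested is made for them only; others in the source may bear on it.

- compound 1 `C=C1[C@H](OC(=O)CC(C)C)C[C@H](OC(C)=O)[C@@]2(C)[C@@H](OC(C)=O)[C@@H](OC(=O)CC(C)C)[C@@H](OC(C)=O)[C@]3(CO3)[C@@H]2[C@H](OC(C)=O)[C@]2(O)[C@@H](C)C(=O)O[C@H]2[C@H]1Cl` gives 19100 nM 
- compound 2 `C=C1[C@H](OC(C)=O)C[C@H](OC(C)=O)[C@@]2(C)[C@@H](OC(C)=O)C[C@@H](OC(=O)CC(C)C)[C@]3(CO3)[C@@H]2[C@H](OC(C)=O)[C@]2(O)[C@@H](C)C(=O)O[C@H]2[C@H]1Cl` gives 16900 nM 
- compound 3 `C=C1[C@H]2O[C@]3([C@@H](C)C(=O)O[C@H]3[C@H]1Cl)[C@@H](OC(C)=O)[C@H]1[C@@]3(CO3)[C@H](OC(=O)CC(C)C)C[C@H](OC(C)=O)[C@]1(C)[C@@H](OC(C)=O)[C@H]2OC(C)=O` gives < 300 nM as a limit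

All three entries come from a functional assay on A549 cells (Homo sapiens) for cytotoxicity, read by MTT assay (on this read-out lower numbers stand for stronger inhibition and higher numbers for weaker inhibition), and the values of compound 1 and compound 2 lie within the usual scatter of each other. The entry for compound 3 is a limit and not a number. Compound 1 and compound 2 both stand at far higher numbers than that limit.

Compound 4 `C=C1[C@H]2O[C@]3([C@@H](C)C(=O)O[C@H]3[C@H]1Cl)[C@@H](OC(C)=O)[C@H]1[C@@]3(CO3)[C@H](OC(C)=O)C[C@H](OC(C)=O)[C@]1(C)[C@@H](OC(C)=O)[C@H]2OC(C)=O` keeps the shared core of compound 3 with one change: hydrogen in place of isopropyl on a saturated chain carbon bound to a carbonyl carbon. Read one bond further out, (isobutylcarbonyl)oxy becomes acetoxy.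

Among the compounds with values here, no measured pair isolates this change. The expectation rests on compound 3 with its limit of < 300 nM as the nearest structure. In this assay the expected step is an at least 1.3-fold higher number from compound 3 to compound 4 (0.12 log units; that floor lies within the scatter) and it is estimated as small, toward weaker inhibition if it shows beyond the scatter at all. For compound 4 the estimated value is 400 nM with an expected range from 80 nM to 3000 nM and a report as a limit would be no surprise.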

Compound 4, half-maximal inhibitory concentration: > 45700 nM
Compound 4: no number, only a limit; the forecaster's own chance of this, stated with the estimate: 40%; at least 110-fold (2.05 log units) between middle value and limit.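

Within the data shown here, the pair compound 3 and compound 4 is the first that differs in one place. In this assay, hydrogen in place of isopropyl on a saturated chain carbon bound to a carbonyl carbon, with the rest of the shared core kept, gives an at least 150-fold higher number from compound 3 to compound 4 (2.18 log units; beyond the scatter), beyond the scatter. Compound 1 and compound 2 each differ from compound 3 in more than one place and could not tie the gap in read-out to any single group, whereas this pair shows that losing the isopropyl end of this one ester chain, turning (isobutylcarbonyl)oxy into acetoxy, is enough on its own to take away the low reading of compound 3. Each end of the step is a limit and not a number, so its printed size is only a floor: the limit of > 45700 nM in this assay, at which 1 of the 4 values shown sits.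

Still open, going by these compounds, is how much of the chain is needed, which a propionyloxy ester or a longer chain at this place would show, and whether a free hydroxyl there behaves like acetoxy. Also open, on these data alone, is whether the same change carries the same weight on the cores of compound 1 and compound 2.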